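Three Benzamide Variants and a Chlorophenyl Candidate at Orexin-2

The source may report more compounds than this note shows. Statements on the series, on what has been measured and on what is new or still open speak of the compounds shown alone.

Measured compounds:
- compound 1, `COc1ccc(-c2cccc(C(=O)N(C)C)c2)cc1S(=O)(=O)Nc1cccc(NCCNC(=O)c2ccccc2)c1`: "not active" (no number reported)
- compound 2, `COc1ccc(C(=O)NCCNc2cccc(NS(=O)(=O)c3cc(-c4cccc(C(=O)N(C)C)c4)ccc3OC)c2)cc1`: 94%
- compound 3, `COc1ccc(-c2cccc(C(=O)N(C)C)c2)cc1S(=O)(=O)Nc1cccc(NCCNC(=O)c2ccccc2C)c1`: 85%

All three share one core and differ only in the group on the carbonyl carbon of the amide at the end of the chain. In a functional assay on CHO-K1 cells for agonist activity at Orexin receptor type 2 (Homo sapiens), read by calcium flux (on this read-out lower numbers stand for smaller maximal responses and higher numbers for larger maximal responses), compound 1 is reported as "not active" (no number reported), with no number given. Compound 2 gives 94% in this assay. Compound 3 gives 85% in this assay, the lowest of the two numbers reported, though the step of a number 9 percentage points lower from compound 2 to compound 3 (within the scatter) is within the scatter, so the two cannot be ordered.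

Compound 4, `COc1ccc(-c2cccc(C(=O)N(C)C)c2)cc1S(=O)(=O)Nc1cccc(NCCNC(=O)c2cccc(Cl)c2)c1`, has not been measured. It differs from compound 3 as follows: 3-chlorophenyl in place of 2-methylphenyl on a carbonyl carbon. Among the compounds with values here, only one measured step bears on this place, a number 9 percentage points lower from compound 2 to compound 3 (within the scatter), and it stayed within the scatter. Compound 1, bearing a plain phenyl at the same place, stands apart as not active, so the change is not without risk. Given that the only known step here was small, compound 4 is expected to stay near compound 3, with the step of a number 5 percentage points lower from compound 3 to compound 4 (within the scatter) estimated as within the scatter. Compound 4 is therefore estimated to give 80% in this assay, within 40% to 100%.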

Compound 4, largest response reached (Emax), in percent of the reference or control that the assay uses: 78%
For compound 4 the middle estimate is 2 percentage points above the measured one, within the range that was stated.
By their numbers in this assay, from the lowest: compounds 4, 3 and 2 (each within the scatter of the next, the first and the last beyond it).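

Within the data shown here, on the carbonyl carbon, the 3-chlorophenyl group brings a halogen into this series for the first time, and the response in this assay holds, with a number 7 percentage points lower from compound 3 to compound 4 (within the scatter). Among these compounds, the comparison with the 4-methoxyphenyl group gives the first step at this place that clears the scatter, though only modestly, with a number 16 percentage points lower from compound 2 to compound 4 (beyond the scatter). All three compounds with a substituted phenyl ring now give a number, whereas compound 1, with the plain phenyl, is reported as "not active" (no number reported). Nothing given here accounts for these steps.

The compounds shown leave open whether a ring carrying an aminomethyl group or a carboxylic acid would still give a response at this place. They also leave open whether a pyridine ring or a cyclohexyl group could stand in for the phenyl ring.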